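This account rests on a few compounds, and the source may have more. Where it says the series, first, only, none or still open, it means among the compounds named here.

Compound 1 (`COc1cc2c(Oc3ccc(NC(=O)Nc4ccccc4)cc3)ccnc2cc1OCCCCCCC(=O)NO`) and compound 2 (`COc1cc2c(Oc3ccc(NC(=O)NC4CCCCC4)cc3)ccnc2cc1OCCCCCCC(=O)NO`) share one core and differ only in the group on an amide-type nitrogen. In a functional assay on MCF7 cells (Homo sapiens) for antiproliferative activity, read by MTT assay (a lower number here means a stronger inhibitor, a higher number a weaker inhibitor), compound 1 gives 1040 nM and compound 2 gives 600 nM. Within the data shown here, these are the only two numbers so far, and the single measured step between them is a 1.7-fold lower number from compound 1 to compound 2 (0.24 log units; within the scatter). Among the measured compounds shown here, compound 2 thus stands level with its one neighbour and has no real lead over it.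

Compound 3 (`COc1cc2c(Oc3ccc(NC(=O)N/N=C/c4ccccc4F)cc3)ccnc2cc1OCCCCCCC(=O)NO`) keeps the same core and changes the same place, with this difference: a group of 9 heavy atoms (7 carbon, 1 nitrogen, 1 fluorine; one six-membered aromatic ring of carbon only) in place of a group of 6 heavy atoms (6 carbon; one six-membered non-aromatic ring of carbon only), on an amide-type nitrogen. For the measured compounds named here, the only measured step that bears on this change is the one at that same nitrogen, a 1.7-fold lower number from compound 1 to compound 2 (0.24 log units; within the scatter), which stayed small. It is a loose guide, however, since the entering group here is larger and holds a double bond outside aromatic rings. No step beyond the scatter is expected in this assay, in either direction, though the uncertainty remains wide. The expected step is a 1.3-fold higher number from compound 2 to compound 3 (0.10 log units; within the scatter). The estimate for compound 3 is 750 nM, expected to fall between 250 nM and 2200 nM.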

Compound 3, half-maximal inhibitory concentration: 1610 nM
For compound 3 the middle estimate is 2.1-fold (0.33 log units) below the measured one; low and high end bracket the measured number.
By their numbers in this assay, from the lowest: compounds 2, 1 and 3 (each within the scatter of the next, the first and the last beyond it).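

In this assay, the amide-type nitrogen now shows its first step beyond the scatter, with a 2.7-fold higher number from compound 2 to compound 3 (0.43 log units; beyond the scatter) when cyclohexyl gives way to the group of 9 heavy atoms that carries an aromatic ring, a fluorine and a double bond outside aromatic rings. Among these compounds, this shows that the position does not accept every group alike, although the effect is modest and appears in only one of the two comparisons: set against the phenyl group of compound 1, the same entering group gives a 1.5-fold higher number from compound 1 to compound 3 (0.19 log units; within the scatter) and so stays within the scatter. No evidence is available to explain the difference seen at this nitrogen.

On these data alone, it remains open which part of the entering group goes with the step from cyclohexyl, as the fluorine, the double bond and the greater size all arrive together in compound 3. Also open, as far as these compounds go, is how the number would respond to a simple benzyl group, a morpholine ring or a chlorine on the aromatic ring at this same nitrogen.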